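A few compounds are considered here, and "the series" means these few. Any claim that something is new, unique, unknown or untested is made for them only; others in the source may bear on it.

Compound 1 `CC1=C(N2CC2)C(=O)C(CC(C)OC(N)=O)=C(N2CC2)C1=O` sits at the top of the three numbers in hand: in a functional assay on L1210 cells (Mus musculus), with a stated time of 12 days (on this read-out lower numbers stand for lower potency and higher numbers for higher potency (the scale is a negative logarithm)), compound 1 gives 6.14. Compound 2 `COCCOC(COC(N)=O)C1=C(N2CC2)C(=O)C(C)=C(N2CC2)C1=O` gives 6.03 in this assay, a number within the scatter of compound 1, so no order between these two is claimed. Compound 3 `CCCC1=C(N2CC2)C(=O)C(CCOC(N)=O)=C(N2CC2)C1=O` gives 5.68, beyond the scatter below compound 1. Within the data shown here, no single-point step among the measured compounds is available, so the move to compound 4 `CC1=C(N2CC2)C(=O)C(N2CC2)=C(N2CC2)C1=O` has no measured counterpart. The change is a group of 3 heavy atoms (2 carbon, 1 nitrogen; one three-membered non-aromatic ring with 1 hetero atom) in place of a group of 7 heavy atoms (4 carbon, 1 nitrogen, 2 oxygen; no ring), on a double-bonded ring carbon. With nothing measured on this kind of change, the expected step of a number 0.26 log units higher from compound 1 to compound 4 (within the scatter) is small and upward, close to the scatter. Compound 4 is therefore estimated at 6.4 in this assay, within a range of 5.7 to 7.1.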

Compound 4, logarithm of the reciprocal of the active concentration, log(1/C): 6.77
Compound 4: the middle estimate sits 0.37 log units below what was measured, within the range that was stated.
By their numbers in this assay, from the lowest: compound 3; then compounds 2 and 1 (each within the scatter of the next); then compound 4.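

In this assay, the series now has its first step in one place, a number 0.63 log units higher from compound 1 to compound 4 (beyond the scatter), so the group of 7 heavy atoms with no ring is not required on this double-bonded ring carbon for this read-out. An aziridin-1-yl group in its place carries the number upward beyond the scatter. Nothing at hand bears on the reason for this step. Open, from the compounds shown here alone, is whether a primary amine or a chlorine atom on this ring carbon would hold the number. Also open, going by these compounds, is whether the same change gives a similar step on the cores of compound 2 and compound 3.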